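Swapping the Amide Aryl Group: What Compound 4 May Show

The compounds below may be only part of what the source reports. "The series", "measured", "known", "first", "only" and "open" are said of these compounds alone.

Compound 1 `COc1cc2ncnc(Nc3ccc(NC(=O)c4ccccc4C)cc3)c2cc1OC` gives 15000 nM in a functional assay on HepG2 cells (Homo sapiens) for inhibition, read by MTT assay; on this read-out lower numbers stand for stronger inhibition and higher numbers for weaker inhibition.
Compound 2 `COc1cc2ncnc(Nc3ccc(NC(=O)c4ccccc4OC)cc3)c2cc1OC` gives only a limit of the assay, > 100000 nM, in this assay.
Compound 3 `COc1cc2ncnc(Nc3ccc(NC(=O)c4ccc(C(C)(C)C)cc4)cc3)c2cc1OC` likewise gives only a limit of the assay, > 100000 nM, in this assay.

Compound 2 therefore stands at the edge of what this assay can read, and it shares that edge with compound 3, as the limit of > 100000 nM in this assay, at which 2 of the 3 values shown sit, shows. Only compound 1 yields a real number. Compound 4 `COc1cc2ncnc(Nc3ccc(NC(=O)c4ccc(Cl)c(Cl)c4)cc3)c2cc1OC` differs from compound 2 in a single place: 3,4-dichlorophenyl in place of 2-methoxyphenyl on a carbonyl carbon.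

For the measured compounds named here, two measured steps bear on the aryl group of this amide. The first is an at least 6.6-fold higher number from compound 1 to compound 2 (0.82 log units; beyond the scatter). The second is an at least 6.6-fold higher number from compound 1 to compound 3 (0.82 log units; beyond the scatter). Both move away from compound 1 toward the limit, so every aryl variation seen so far has weakened inhibition. The step that the two limits leave unreadable from compound 2 to compound 3 cannot be sized, as both of its values are limits.

Going by the values given here, the change to compound 4 is another aryl swap of the same kind, with no measured step pointing toward stronger inhibition. Compound 4 is therefore expected to remain weak, with a fair chance of a limit again, at an estimated 60000 nM within 10000 nM to 200000 nM. The expected step is an at least 1.6-fold lower number from compound 2 to compound 4 (0.22 log units; that floor lies within the scatter), which is not readable against a starting limit.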

Compound 4, half-maximal inhibitory concentration: 28000 nM
Compound 4: middle estimate off by 2.1-fold (0.33 log units), on the high side, and the stated range covers the measured number.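

Compound 4 shows that changing the aryl group on this amide carbonyl need not push inhibition to the limit in this assay: 3,4-dichlorophenyl in place of 2-methoxyphenyl gives an at least 3.5-fold lower number from compound 2 to compound 4 (0.55 log units; beyond the scatter), and in place of 4-(tert-butyl)phenyl it gives an at least 3.5-fold lower number from compound 3 to compound 4 (0.55 log units; beyond the scatter). Compared with compound 1, the result is a 1.9-fold higher number from compound 1 to compound 4 (0.27 log units; within the scatter), so 3,4-dichlorophenyl and 2-methylphenyl cannot be told apart on this read-out, and the earlier picture of every departure from compound 1 losing inhibition no longer holds. This position therefore tolerates at least two different aryl groups with a readable value, while compound 2 and compound 3 still give only a limit of the assay, not a number: the limit of > 100000 nM in this assay, at which 2 of the 4 values shown sit.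

The step between compound 2 and compound 3 still cannot be read, as both ends of it are limits. The compounds shown also leave open whether inhibition at this position could become clearly stronger than in compound 1 or compound 4, for instance with a pyridine ring in place of the phenyl ring or with a dimethylamino group on it.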